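The source may report more compounds than this note shows. Statements on the series, on what has been measured and on what is new or still open speak of the compounds shown alone.

Among the compounds with values here, compound 3 `Cn1nnnc1SCC(=O)Nc1ccc(-c2nc(-c3ccccc3)c(-c3ccccc3)n2C)cc1` gives 1.6 ug/mL in a functional assay on HT-29 cells (Homo sapiens) for cytotoxicity, read by MTT assay, with a stated time of 24 h (on this read-out higher numbers stand for weaker inhibition and lower numbers for stronger inhibition), the lowest of the three numbers measured so far. Compound 1 `Cn1c(-c2ccc(NC(=O)CCl)cc2)nc(-c2ccccc2)c1-c1ccccc1` gives 28.7 ug/mL and compound 2 `Cn1cnnc1SCC(=O)Nc1ccc(-c2nc(-c3ccccc3)c(-c3ccccc3)n2C)cc1` gives 10.7 ug/mL; the drops a 2.7-fold lower number from compound 1 to compound 2 (0.43 log units; beyond the scatter) and an 18-fold lower number from compound 1 to compound 3 (1.25 log units; beyond the scatter) both came from replacing the chloro with a ring-bearing sulfur. Compound 4 `Cc1nnc(SCC(=O)Nc2ccc(-c3nc(-c4ccccc4)c(-c4ccccc4)n3C)cc2)s1` differs from compound 3 by 5-methyl-1,3,4-thiadiazol-2-yl in place of 1-methyl-1H-tetrazol-5-yl on a sulfur. Within the data shown here, the one measured step that bears directly on this is the earlier exchange of the ring on the sulfur, a 6.7-fold lower number from compound 2 to compound 3 (0.83 log units; beyond the scatter), which shows that swapping this ring can shift the number well beyond the scatter. A further exchange of the same ring is therefore expected to move the number, most likely upward, by a 3.1-fold higher number from compound 3 to compound 4 (0.49 log units; beyond the scatter). Compound 4 is estimated at 5 ug/mL, with a range from 1.5 ug/mL to 16 ug/mL.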

Compound 4, half-maximal inhibitory concentration: 2.7 ug/mL
The estimate for compound 4 lay 1.9-fold (0.27 log units) above the measured number, and the stated range covers the measured number.
By their numbers in this assay, from the lowest: compounds 3 and 4 (each within the scatter of the next); then compound 2; then compound 1.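

With a 1.7-fold higher number from compound 3 to compound 4 (0.23 log units; within the scatter) for the 5-methyl-1,3,4-thiadiazol-2-yl group in place of the 1-methyl-1H-tetrazol-5-yl group, these two rings on the sulfur cannot be told apart here. Both a 4.0-fold lower number from compound 2 to compound 4 (0.60 log units; beyond the scatter) and an 11-fold lower number from compound 1 to compound 4 (1.03 log units; beyond the scatter) lie beyond the scatter, so of the three rings on this sulfur the 4-methyl-4H-1,2,4-triazol-3-yl group is the one that stands apart. No measurement at hand explains why.

The compounds shown leave open whether a ring is needed at this place at all, which a plain amine such as dimethylamino or a carboxylic acid on the saturated chain carbon would help to answer.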